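Furan-2-yl to thiophen-2-yl: the step to compound 4

The compounds below may be only part of what the source reports. "The series", "measured", "known", "first", "only" and "open" are said of these compounds alone.

In a functional assay on G-361 cells (Homo sapiens) for inhibition, with a stated time of 72 h (a lower number here means a stronger inhibitor, a higher number a weaker inhibitor), compound 1 `NC1CCC(Nc2nc(NCc3ccc(-c4ccco4)cc3)c3ncn(C4CCCC4)c3n2)CC1` gives 164 nM, compound 2 `NC1CCC(Nc2nc(NCc3ccc(-c4ccccc4)nc3)c3ncn(C4CCCC4)c3n2)CC1` gives 895 nM and compound 3 `NC1CCC(Nc2nc(NCc3ccc(-c4ccco4)nc3)c3ncn(C4CCCC4)c3n2)CC1` gives 97 nM. The two furan-2-yl compounds are not separated, with a gap of a 1.7-fold lower number from compound 1 to compound 3 (0.23 log units; within the scatter). Compound 4 `NC1CCC(Nc2nc(NCc3ccc(-c4cccs4)nc3)c3ncn(C4CCCC4)c3n2)CC1` carries one change: thiophen-2-yl in place of furan-2-yl on an aromatic carbon. Among the compounds with values here, the only measured change at this place is phenyl to furan-2-yl, a 9.2-fold lower number from compound 2 to compound 3 (0.97 log units; beyond the scatter), a modest step beyond the scatter. Thiophen-2-yl is, like furan-2-yl, a five-membered aromatic ring with 1 hetero atom, but no thiophen-2-yl compound has been measured yet. No step beyond the scatter is expected in this assay. The estimated move is a 1.3-fold higher number from compound 3 to compound 4 (0.13 log units; within the scatter). For compound 4 the expected value is 130 nM, with an estimated range of 50 nM to 340 nM.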

Compound 4, half-maximal inhibitory concentration: 150 nM
The estimate for compound 4 lay 1.2-fold (0.06 log units) below the measured number; the measured number falls inside the stated range.
By their numbers in this assay, from the lowest: compounds 3, 4 and 1 (each within the scatter of the next); then compound 2.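

Exchanging the hetero atom of the five-membered ring leaves the number in this assay unmoved at this position (a 1.5-fold higher number from compound 3 to compound 4 (0.19 log units; within the scatter)), and the 6-(thiophen-2-yl)pyridin-3-yl and 4-(furan-2-yl)phenyl compounds are likewise not separated (a 1.1-fold lower number from compound 1 to compound 4 (0.04 log units; within the scatter)). The gap to phenyl now rests on a second five-membered ring (a 6.0-fold lower number from compound 2 to compound 4 (0.78 log units; beyond the scatter)), so it is not particular to furan-2-yl. No evidence at hand accounts for that gap. Open, as far as these compounds go, is whether a ring with two hetero atoms, such as thiazol-2-yl, or a small group such as methyl, stays near compound 3 or falls towards compound 2.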